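The source may report more compounds than this note shows. Statements on the series, on what has been measured and on what is new or still open speak of the compounds shown alone.

Compound 3, `Nc1cc(Br)ccc1NC(=O)c1ccc(CNc2nccc(-c3cccnc3)n2)cc1`, is one of three close analogues that share a core and differ only in the group on an amide-type nitrogen. In an assay on isolated protein for inhibition of protein deacetylase HDAC6 (Homo sapiens), read by fluorescence, with stated times of 3 h and 60 min (a lower number here means a stronger inhibitor, a higher number a weaker inhibitor), compound 3 reaches only the limit of > 20000 nM. Compound 1, `Nc1cc2ccccc2cc1NC(=O)c1ccc(CNc2nccc(-c3cccnc3)n2)cc1`, likewise gives only the limit of > 20000 nM in this assay. Compound 2, `Nc1cc(C(=O)O)ccc1NC(=O)c1ccc(CNc2nccc(-c3cccnc3)n2)cc1`, also sits at the limit of > 20000 nM in this assay. The steps among them, a step that the two limits leave unreadable from compound 1 to compound 2, a step that the two limits leave unreadable from compound 1 to compound 3 and a step that the two limits leave unreadable from compound 2 to compound 3, therefore have no readable size, and compound 3 stands with the other two at the limit of > 20000 nM in this assay, at which 3 of the 3 values shown sit. Compound 4, `O=C(NO)c1ccc(CNc2nccc(-c3cccnc3)n2)cc1`, has not yet been measured in this assay. It differs from compound 3 by hydroxy in place of 2-amino-4-bromophenyl on an amide-type nitrogen. Among the compounds with values here, no measured step bears on this exchange, so the three limits give no direction or size for it; the estimate below rests on the change alone. Compound 4 is expected to give about 30 nM in this assay, within 3 nM to 500 nM, which would mean an expected step of an at least 660-fold lower number from compound 3 to compound 4 (2.82 log units; beyond the scatter).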

Compound 4, half-maximal inhibitory concentration: 42 nM
Estimate against measurement, compound 4: 1.4-fold (0.15 log units) below; low and high end bracket the measured number.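

At this position on the amide-type nitrogen, hydroxy is the first group shown to give a readable number in this assay, and the exchange is large against all three earlier groups: an at least 470-fold lower number from compound 3 to compound 4 (2.67 log units; beyond the scatter), an at least 470-fold lower number from compound 2 to compound 4 (2.67 log units; beyond the scatter) and an at least 470-fold lower number from compound 1 to compound 4 (2.67 log units; beyond the scatter). The earlier compounds shown here showed only that the bromo, carboxy and fused-ring versions of the aromatic group share one limit, and the steps among them cannot be read. Compound 4 alone departs from that limit: the limit of > 20000 nM in this assay, at which 3 of the 4 values shown sit.

The compounds shown do not separate the effect of adding hydroxy from that of removing the aromatic group, as the exchange does both at once. On these data alone, a methoxy group or an unsubstituted 2-aminophenyl group on that nitrogen remains open, as does how much of the number depends on the shared core.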